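A few compounds are considered here, and "the series" means these few. Any claim that something is new, unique, unknown or untested is made for them only; others in the source may bear on it.

Measured in a toxicity assay on Huh-7 cells (Homo sapiens) for cytotoxicity, with a stated time of 3 days; a higher number here means that more compound is tolerated, a lower number that less compound is tolerated:
- Compound 1 `C[C@@]1(O)[C@H](O)[C@@H](CO)O[C@H]1n1cc(-c2ccccc2)c2c(N)ncnc21`: > 44000 nM
- Compound 2 `C[C@@]1(O)[C@H](O)[C@@H](CO)O[C@H]1n1cc(-c2ccco2)c2c(N)ncnc21`: 49600 nM

The entry for compound 1, > 44000 nM, is a limit of the assay and not a number. Among the compounds with values here, compound 2 gives the only true number so far, 49600 nM, so it cannot yet be ranked against another measured number. Compound 3 `C[C@@]1(O)[C@H](O)[C@@H](CO)O[C@H]1n1cc(-c2cccs2)c2c(N)ncnc21` keeps the shared core and carries thiophen-2-yl in place of furan-2-yl on an aromatic carbon. Within the data shown here, only one measured step bears on this swap of an aromatic group: a step that the limit leaves unreadable from compound 1 to compound 2. With the limit of > 44000 nM in this assay, at which 1 of the 2 values shown sits, that step offers no size to carry over, and it points in no direction. No change beyond the usual scatter is therefore expected in this assay. The expected change is a 1.2-fold lower number from compound 2 to compound 3 (0.07 log units; within the scatter). For compound 3 the estimated value is 42000 nM, with an expected range from 18000 nM to 90000 nM.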

Compound 3, half-maximal cytotoxic concentration: 48100 nM
For compound 3 the middle estimate is 1.1-fold (0.06 log units) below the measured one; measured number inside the range.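

In this assay, this position now has its first readable step: a 1.0-fold lower number from compound 2 to compound 3 (0.01 log units; within the scatter). On this aromatic carbon of the shared core, a five-membered aromatic ring holding oxygen and one holding sulfur therefore cannot be told apart by this read-out. The steps from compound 1 remain unreadable, and the reason is a limit: the limit of > 44000 nM in this assay, at which 1 of the 3 values shown sits.

From the compounds shown here alone, it remains open how the phenyl group of compound 1 truly compares with the furan-2-yl and thiophen-2-yl groups, since only a limit stands for it. Also open, going by these compounds, is whether an amine or a carboxylic acid on this aromatic carbon, in place of an aromatic ring, would give a number beyond the usual scatter of this assay.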